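A few compounds are considered here, and "the series" means these few. Any claim that something is new, unique, unknown or untested is made for them only; others in the source may bear on it.

Measured so far:
compound 1, `COc1cccc(/C=C/c2ccccc2O)c1`: 26 ug/mL
compound 2, `COc1ccc(/C=C/c2cccc(O)c2)cc1`: 22 ug/mL
compound 3, `COc1cccc(/C=C/c2ccccc2N)c1`: 21.2 ug/mL

All three were tested in a functional assay on HT-29 cells (Homo sapiens) for inhibition, read by MTT assay, with a stated time of 2 days; a higher number here means a weaker inhibitor, a lower number a stronger inhibitor. Compound 3 differs from compound 1 by one change, (amino in place of hydroxy on an aromatic carbon), and this gave a 1.2-fold lower number from compound 1 to compound 3 (0.09 log units; within the scatter). Compound 2 has the same atoms as compound 1 joined differently; the difference between the two cores is not broken down here, and their values lie within the scatter of each other. Compound 4, `COc1ccc(/C=C/c2cccc(N)c2)cc1`, has not been measured. It differs from compound 2 by amino in place of hydroxy on an aromatic carbon. This is the same kind of change as from compound 1 to compound 3, though in compound 4 the new group sits meta to a large group rather than ortho to a large group. Because the earlier step of a 1.2-fold lower number from compound 1 to compound 3 (0.09 log units; within the scatter) stayed within the scatter, a similar outcome is expected, with an estimated step of a 1.1-fold lower number from compound 2 to compound 4 (0.04 log units; within the scatter) in this assay. Compound 4 is therefore estimated at 20 ug/mL, between 10 ug/mL and 40 ug/mL.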

Compound 4, half-maximal inhibitory concentration: 16.3 ug/mL
Compound 4: middle estimate off by 1.2-fold (0.09 log units), on the high side, and the stated range covers the measured number.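

Putting amino in place of hydroxy on the core of compound 2 gave a 1.3-fold lower number from compound 2 to compound 4 (0.13 log units; within the scatter) in this assay. The same change on the two cores gave steps of much the same small size: the same change on two cores in this assay, a 1.2-fold lower number (0.09 log units; within the scatter) from compound 1 to compound 3 and a 1.3-fold lower number (0.13 log units; within the scatter) from compound 2 to compound 4, 1.1-fold (0.04 log units) apart, within the scatter of two such steps

Both steps lie within the scatter, so the two cores agree with each other, but they do not show that amino and hydroxy really differ in this assay, and two cores set no rule for the wider series.

Still open, on these data alone, is whether a different group in the same place, such as a carboxylic acid or an amide, would move the number beyond the scatter. Also open, as far as these compounds go, is whether the swap would stay this small on other cores.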